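The compounds below may be only part of what the source reports. "The series", "measured", "known", "first", "only" and "open" are said of these compounds alone.

In an assay on isolated protein for inhibition of Calpain-1 catalytic subunit (Sus scrofa), read by FRET (a lower number here means a stronger inhibitor, a higher number a weaker inhibitor), compound 1 `O=C(O)/C(S)=C/c1c[nH]c2cc(Br)ccc12` gives 7 nM, while compound 2 `O=C(O)/C(S)=C/c1c[nH]c2cc(Cl)ccc12` gives 210 nM. For the measured compounds named here, the single change between them, (chloro in place of bromo on an aromatic carbon), produces a 30-fold higher number from compound 1 to compound 2 (1.48 log units; beyond the scatter). Compound 3 `O=C(O)/C(S)=C/c1c[nH]c2c(Br)cccc12` gives 2 nM in this assay, the lowest of the three numbers; how its core differs from the core of compound 1 is not broken down here. Compound 4 `O=C(O)/C(S)=C/c1c[nH]c2c(Cl)cccc12` has not been measured in this assay. It differs from compound 3 by chloro in place of bromo on an aromatic carbon, the same kind of change as that between compound 1 and compound 2, but not the same: here the halogen is ortho to a fused ring and meta to a fused ring, whereas in compound 1 it is meta to a fused ring and para to a fused ring. For compound 4 a step of the same kind is expected, estimated as a 20-fold higher number from compound 3 to compound 4 (1.30 log units; beyond the scatter), resting on the size of a 30-fold higher number from compound 1 to compound 2 (1.48 log units; beyond the scatter), with a wider range since the surroundings of the change differ. Compound 4 is thus estimated at 40 nM, between 8 nM and 200 nM.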

Compound 4, half-maximal inhibitory concentration: 10 nM
Estimate against measurement, compound 4: 4.0-fold (0.60 log units) above; the measured number falls inside the stated range.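

In this assay, chloro in place of bromo on an aromatic carbon again gives a higher number, here a 5.0-fold higher number from compound 3 to compound 4 (0.70 log units; beyond the scatter), so the direction of the step carries from one core to the other but its size does not: the same change on two cores in this assay, a 30-fold higher number (1.48 log units; beyond the scatter) from compound 1 to compound 2 and a 5.0-fold higher number (0.70 log units; beyond the scatter) from compound 3 to compound 4, 6.0-fold (0.78 log units) apart, beyond the scatter of two such steps. For this series, the size of the step on one core is therefore no fixed value to apply to the other. Two pairs do not show why the sizes differ, or what size the change would have on any further core.

The compounds shown leave open how fluoro, iodo or methoxy would compare with bromo and chloro on the same aromatic carbon of either core. Also open, from the compounds shown here alone, is whether the same direction would hold for those groups.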